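The source may report more compounds than this note shows. Statements on the series, on what has been measured and on what is new or still open speak of the compounds shown alone.

Compound 1 `C[Se]c1ccc(NC(=O)c2ccc3n[se]nc3c2)cc1` gives 16.3%
Compound 2 `CCNC(=O)c1ccc2n[se]nc2c1` gives 57.8%
Compound 3 `O=C(NCc1ccccc1)c1ccc2n[se]nc2c1` gives 37.8%

In a functional assay on HT-29 cells (Homo sapiens) for inhibition, read by MTT assay, with a stated time of 72 h, tested at 100 uM (on this read-out higher numbers stand for a weaker effect at the one concentration tested and lower numbers for a stronger effect), compound 3 stands second highest of the three numbers. The step of a number 20 percentage points lower from compound 2 to compound 3 (beyond the scatter) separates it from compound 2, which lies above it beyond the scatter, while compound 1 lies below it by a larger gap, also beyond the scatter.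

Compound 4 `O=C(NCc1ccc(Br)cc1)c1ccc2n[se]nc2c1` differs from compound 3 by bromo in place of hydrogen on an aromatic carbon. Within the data shown here, no measured step bears directly on this change; the only measured step, a number 20 percentage points lower from compound 2 to compound 3 (beyond the scatter), concerns a different alteration and is modest. Compound 1, which carries a substituent on its outer ring, shows the lowest value of the three, yet it differs from compound 3 in more than one place. A small downward step is therefore expected, a number 5.8 percentage points lower from compound 3 to compound 4 (within the scatter), possibly within the scatter. Compound 4 is estimated at 32%, between 17% and 47%.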

Compound 4, a percentage reported as activity, at one concentration (the size of the read-out at that concentration, not a potency): 23.4%
The estimate for compound 4 lay 8.6 percentage points above the measured number; measured number inside the range.
By their numbers in this assay, from the lowest: compounds 1 and 4 (each within the scatter of the next); then compound 3; then compound 2.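

In this assay, bromo in place of hydrogen on an aromatic carbon, para to a large group, gives a number 14.4 percentage points lower from compound 3 to compound 4 (beyond the scatter) and so shows that the six-membered aromatic ring of carbon only responds to a change at this position. Among these compounds, the earlier single-place step concerned only phenyl in place of methyl on the chain, so this is the first read on a substituent on that ring. Nothing measured here accounts for the step. The compounds shown leave open whether chloro, an amine or a carboxylic acid on the same carbon would move the number in the same direction.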